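Aromatic nitrogen substituent: phenyl for 2-fluorobenzyl

The source may hold more compounds than are shown below. What is called first, only, known or untested is meant among the compounds shown, and "the series" means these compounds.

Compound 1, `CCOC(=O)c1ccc(-c2nn(Cc3ccccc3F)c3ccccc23)cc1`, gives 110 nM in a functional assay on cells (Platelet, Homo sapiens) for inhibition; on this read-out lower numbers stand for stronger inhibition and higher numbers for weaker inhibition. Compound 2, `CCNC(=O)c1ccc(-c2nn(Cc3ccccc3)c3ccccc23)cc1`, gives 5640 nM in this assay. Compound 3, `CC(C)NC(=O)c1ccc(-c2nn(Cc3ccccc3)c3ccccc23)cc1`, reaches only a limit of this assay rather than a number, > 10000 nM, the one case of the limit of > 10000 nM in this assay, at which 1 of the 3 values shown sits, among the three values. Of the two numbers in hand, compound 1 holds the lower one, and its nearest neighbour compound 2 lies beyond the scatter above it. Among the measured compounds shown here, the single measured step, an at least 1.7-fold higher number from compound 2 to compound 3 (0.24 log units; that floor lies within the scatter), concerns the amide substituent and leaves the aromatic nitrogen untouched.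

Compound 4, `CCOC(=O)c1ccc(-c2nn(-c3ccccc3)c3ccccc23)cc1`, differs from compound 1 at that nitrogen: phenyl in place of 2-fluorobenzyl on an aromatic nitrogen. For the measured compounds named here, no measured step covers this position, so the series gives no direction for the change; a step beyond the scatter either way stays possible, and the range is set wide. Compound 4 is therefore expected near 300 nM, within 60 nM to 2000 nM. This estimate corresponds to an expected step of a 2.7-fold higher number from compound 1 to compound 4 (0.44 log units; beyond the scatter) in this assay.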

Compound 4, half-maximal inhibitory concentration: 2640 nM
The estimate for compound 4 lay 8.8-fold (0.94 log units) below the measured number; the measured number lies above the stated range.
By their numbers in this assay, from the lowest: compound 1; then compound 4; then compound 2. At a limit, above all of these: compound 3.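

Among the compounds shown here, this is the first measured step at the aromatic nitrogen, and it is large: in this assay, phenyl in place of 2-fluorobenzyl gives a 24-fold higher number from compound 1 to compound 4 (1.38 log units; beyond the scatter). With the ethyl ester held constant, the substituent at this nitrogen therefore has a strong bearing on inhibition, though the step changes the link to the ring and removes the fluorine together, so it does not separate the two. Nothing in hand gives a cause for this step.

Open, from the compounds shown here alone, is whether plain benzyl on this nitrogen, with the ethyl ester kept, stays near compound 1, and whether a longer link such as 2-phenylethyl changes the number further. Also open, going by these compounds, is how a carboxylic acid in place of the ethyl ester would read out with 2-fluorobenzyl on the nitrogen.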